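From phenyl to 4-chlorophenyl on compound 1

This account rests on a few compounds, and the source may have more. Where it says the series, first, only, none or still open, it means among the compounds named here.

Of the compounds shown here, two sharing one core have numbers so far. In a functional assay on SF-295 cells (Homo sapiens) for antiproliferative activity, read by sulforhodamine B assay, with a stated time of 72 h (a higher number here means a weaker inhibitor, a lower number a stronger inhibitor), compound 1 (`C(=C/c1ccccc1)\C(=N\Nc1nncc2ccccc12)c1ccccc1`) gives 0.33 nM, the lower of the two numbers. Compound 2 (`S=C(NNc1nncc2ccccc12)Nc1ccccc1`) gives 9.5 nM, and the gap between the two lies beyond the scatter. Compound 1 is therefore the stronger inhibitor of this pair and the reference point for the next comparison.

Compound 3 (`Clc1ccc(C(/C=C/c2ccccc2)=N\Nc2nncc3ccccc23)cc1`) has not yet been measured in this assay. It keeps the core of compound 1 and carries chloro in place of hydrogen on an aromatic carbon, para to a large group, turning phenyl into 4-chlorophenyl: chloro in place of hydrogen on an aromatic carbon. Going by the values given here, no measured pair differs in only one place, so the size of this change has no direct precedent here. Among the compounds with values here, the only anchor is compound 1 at 0.33 nM, and a small change is the cautious expectation, with a slight lean towards a higher number. The expected 1.5-fold higher number from compound 1 to compound 3 (0.18 log units; within the scatter) stays within the scatter. For compound 3 the estimated value is 0.5 nM, with an expected range of 0.12 nM to 2 nM.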

Compound 3, half-maximal inhibitory concentration: 0.53 nM
Estimate against measurement, compound 3: 1.1-fold (0.03 log units) below, within the range that was stated.
By their numbers in this assay, from the lowest: compounds 1 and 3 (each within the scatter of the next); then compound 2.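

In this assay, going by these compounds alone, the only step that changes one place reads a 1.6-fold higher number from compound 1 to compound 3 (0.21 log units; within the scatter), so chloro in place of hydrogen on this aromatic carbon gives no change that can be told from the scatter. Within the data shown here, this is the first direct reading at this position, para to a large group. Compound 3, at 0.53 nM, shows that phenyl to 4-chlorophenyl is accepted here without leaving the range of compound 1, although no measurement shown explains this result.

From the compounds shown here alone, a single step with a single substituent sets no trend, so it remains open whether a methoxy group, an amine or a carboxylic acid at the same position would also keep the number close to that of compound 1. Also open, going by these compounds, is whether chloro placed on the other phenyl ring of compound 1 would behave as it does here, and whether this tolerance would carry over to the thiourea-type chain of compound 2.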